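Iodo for Ethynyl on a Methoxy-Bearing Core

This account rests on a few compounds, and the source may have more. Where it says the series, first, only, none or still open, it means among the compounds named here.

Compound 1, `Cc1ncnc2c1c(I)cn2[C@@H]1O[C@H](CO)[C@@H](O)[C@H]1O`, gives 2650 nM in a functional assay on HL-60 cells (Homo sapiens) for antiproliferative activity, read by XTT assay, with a stated time of 72 h; on this read-out lower numbers stand for stronger inhibition and higher numbers for weaker inhibition.
Compound 2, `C#Cc1cn([C@@H]2O[C@H](CO)[C@@H](O)[C@H]2O)c2ncnc(C)c12`, gives 1110 nM in this assay.
Compound 3, `C#Cc1cn([C@@H]2O[C@H](CO)[C@@H](O)[C@H]2O)c2ncnc(OC)c12`, gives 190 nM in this assay.

Compound 4, `COc1ncnc2c1c(I)cn2[C@@H]1O[C@H](CO)[C@@H](O)[C@H]1O`, has not yet been measured. It differs from compound 3 by iodo in place of ethynyl on an aromatic carbon. The same change has been measured once already, from compound 2 to compound 1, as iodo in place of ethynyl on an aromatic carbon, where it gave a 2.4-fold higher number from compound 2 to compound 1 (0.38 log units; beyond the scatter). The two cores differ in that compound 3 carries methoxy in place of methyl on an aromatic carbon relative to compound 2, and that change on its own gave a 5.8-fold lower number from compound 2 to compound 3 (0.77 log units; beyond the scatter). Because a 2.4-fold higher number from compound 2 to compound 1 (0.38 log units; beyond the scatter) was only a modest weakening, a step of similar size is expected from compound 3 to compound 4, namely a 2.4-fold higher number from compound 3 to compound 4 (0.37 log units; beyond the scatter). Compound 4 is therefore estimated at 450 nM, most likely between 200 nM and 1100 nM.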

Compound 4, half-maximal inhibitory concentration: 2300 nM
Compound 4: middle estimate off by 5.1-fold (0.71 log units), on the low side; the measured number lies above the stated range.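

In this assay, iodo in place of ethynyl gave a 12-fold higher number from compound 3 to compound 4 (1.08 log units; beyond the scatter), a much larger step than on the methyl-bearing core: the same change on two cores in this assay, a 2.4-fold higher number (0.38 log units; beyond the scatter) from compound 2 to compound 1 and a 12-fold higher number (1.08 log units; beyond the scatter) from compound 3 to compound 4, 5.1-fold (0.71 log units) apart, beyond the scatter of two such steps. Methoxy in place of methyl gave a 1.2-fold lower number from compound 1 to compound 4 (0.06 log units; within the scatter), so the advantage it showed with ethynyl did not appear with iodo: the same change on two cores in this assay, a 5.8-fold lower number (0.77 log units; beyond the scatter) from compound 2 to compound 3 and a 1.2-fold lower number (0.06 log units; within the scatter) from compound 1 to compound 4, 5.1-fold (0.71 log units) apart, beyond the scatter of two such steps. Iodo gave a higher number on both cores, but the size of neither step carried from one core to the other, and these four compounds cannot show why the two changes depend on each other.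

As far as these compounds go, it remains open whether a bromo or a longer chain such as propynyl in place of ethynyl would behave like ethynyl or like iodo. From the compounds shown here alone, it is equally open how an amine in place of methoxy or methyl would pair with either group.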